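The source may hold more compounds than are shown below. What is called first, only, known or untested is meant among the compounds shown, and "the series" means these compounds.

Measured in a functional assay on DU-145 cells (Homo sapiens) for antiproliferative activity, read by WST assay, with a stated time of 3 days; on this read-out higher numbers stand for weaker inhibition and lower numbers for stronger inhibition:
- compound 1 `CCN(CC)CCCCCOc1c(-c2cc(OC)c(OC)c(OC)c2)oc2ccccc2c1=O`: 33400 nM
- compound 2 `CCCCN(CCCC)CCCCOc1c(-c2cc(OC)c(OC)c(OC)c2)oc2ccccc2c1=O`: 15300 nM

Of these two, compound 2 has the lower number at 15300 nM, and so the stronger inhibition. The next compound, compound 3 `CCCCN(CCCC)CCCCCOc1c(-c2cc(OC)c(OC)c(OC)c2)oc2ccccc2c1=O`, is not yet measured in this assay. It differs from compound 2 as follows: (dibutylamino)methyl in place of dibutylamino on a saturated chain carbon, four bonds along the chain from an oxygen on an aromatic ring. In words, (dibutylamino)methyl stands in place of dibutylamino on a saturated chain carbon.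

For the measured compounds named here, only one measured step bears on this change: a 2.2-fold lower number from compound 1 to compound 2 (0.34 log units; beyond the scatter). That step is modest, and it swaps the amine and shortens the chain together, so the data cannot separate the two changes. Going by the values given here, no measured step isolates the added carbon alone. No change beyond the scatter is therefore expected, with at most a slight lean towards a lower number. The estimated step is a 1.2-fold lower number from compound 2 to compound 3 (0.07 log units; within the scatter). Compound 3 is expected at 13000 nM, within an estimated range of 5000 nM to 32000 nM.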

Compound 3, half-maximal inhibitory concentration: > 50000 nM
Compound 3 was reported as a limit; the forecaster's own chance of this, stated with the estimate: 8%; middle value at least 3.8-fold (0.58 log units) from the limit.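

In this assay, (dibutylamino)methyl in place of dibutylamino gives an at least 3.2-fold higher number from compound 2 to compound 3 (0.51 log units; beyond the scatter), so this change alone moves the read-out beyond the scatter, which the earlier pair, with its amine and chain changing together, could not show. With the chain held the same, dibutylamino in place of diethylamino gives an at least 1.4-fold higher number from compound 1 to compound 3 (0.17 log units; that floor lies within the scatter), and that floor lies within the scatter, so the amine swap on this chain shows no clear effect so far. The reading for compound 3 is a limit and not a number: the limit of > 50000 nM in this assay, at which 1 of the 3 values shown sits.

The compounds shown leave open how far the true value of compound 3 lies past that limit. They also leave open whether a shorter chain bearing 2-(dibutylamino)ethyl, or a ring amine such as piperidine or morpholine on either chain, would lower the number further.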